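Sulfur-linked ethyl variants on the shared core

This account rests on a few compounds, and the source may have more. Where it says the series, first, only, none or still open, it means among the compounds named here.

Within the data shown here, in an assay on isolated protein for inhibition of aldehyde dehydrogenase 1A1 (Homo sapiens) (a higher number here means a weaker inhibitor, a lower number a stronger inhibitor), the series so far holds three measured compounds. Compound 1 `Cn1ncc2c(=O)n(-c3ccccc3)c(COc3cccc(F)c3)nc21` gives 8200 nM, compound 2 `Cn1ncc2c(=O)n(-c3ccccc3)c(SC(C)(C)c3ccccc3)nc21` gives 1900 nM, and compound 3 `CC(Sc1nc2c(cnn2C)c(=O)n1-c1ccccc1)c1ccccn1` gives 242 nM. Compound 3 stands at the lowest number of the three: compound 2 is nearest, separated by a 7.9-fold lower number from compound 2 to compound 3 (0.89 log units; beyond the scatter), and compound 1 is furthest, with a far higher number than compound 3. The next compound, compound 4 `COc1ccccc1C(C)Sc1nc2c(cnn2C)c(=O)n1-c1ccccc1`, differs from compound 3 by 2-methoxyphenyl in place of pyridin-2-yl on a saturated chain carbon bound to a saturated chain carbon and a sulfur; the sulfur link and the ethyl chain on it are retained.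

Among the measured compounds shown here, only one measured step bears on this change, a 7.9-fold lower number from compound 2 to compound 3 (0.89 log units; beyond the scatter), which replaced the whole group on the sulfur and was modest in size. The present change keeps the chain and exchanges one ring for another, so a smaller step than that one is expected in this assay, possibly none beyond the scatter. For the measured compounds named here, no measured pair exchanges pyridin-2-yl for 2-methoxyphenyl, so the direction is open; a slightly higher number is taken as the middle case. For compound 4 the expected value in this assay is 400 nM, with a range from 150 nM to 1200 nM. This amounts to an expected step of a 1.7-fold higher number from compound 3 to compound 4 (0.22 log units; within the scatter).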

Compound 4, half-maximal inhibitory concentration: 445 nM
The estimate for compound 4 lay 1.1-fold (0.05 log units) below the measured number; measured number inside the range.
By their numbers in this assay, from the lowest: compounds 3 and 4 (each within the scatter of the next); then compound 2; then compound 1.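

In this assay, the exchange of pyridin-2-yl for 2-methoxyphenyl on a saturated chain carbon bound to a saturated chain carbon and a sulfur gives a 1.8-fold higher number from compound 3 to compound 4 (0.26 log units; within the scatter) and leaves no readable difference between the two rings. Among these compounds, this is the first measured pair that changes only the ring on this ethyl chain, and it shows that, for these two compounds, a ring of carbon only with 8 heavy atoms reads the same as a ring with 1 hetero atom and 6 heavy atoms, so a ring nitrogen is not required at this place. No measurement on hand accounts for the two rings reading alike.

This single step changes the ring atom and adds the methoxy group together, so the compounds shown cannot separate the two changes, and a plain phenyl or a 2-fluorophenyl on the same chain carbon would be needed to do so. Also open, on these data alone, is whether this place accepts a ring carrying an amine or a carboxylic acid, or a longer chain in place of the ethyl link on the sulfur.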